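Three Bis-Amides at the Assay Limit, a Fourth Expected There

The source may report more compounds than this note shows. Statements on the series, on what has been measured and on what is new or still open speak of the compounds shown alone.

Compound 1, `COc1ccccc1C(=O)Nc1cccc(NC(=O)c2ccc(F)cc2)c1`, gives a limit of > 30000 nM in an in vitro functional assay on HEK293-A cells for antagonist activity at metabotropic glutamate receptor 5 (Rattus norvegicus), read by calcium flux; on this read-out lower numbers stand for stronger inhibition and higher numbers for weaker inhibition.
Compound 2, `O=C(Nc1cccc(NC(=O)c2cccc(Cl)c2)c1)c1ccc(Cl)cc1`, gives a limit of > 30000 nM in this assay.
Compound 3, `O=C(Nc1cccc(NC(=O)c2ccc(Cl)c(Cl)c2)c1)c1cccc(Cl)c1`, gives a limit of > 30000 nM in this assay.

Compound 3 therefore stands at the top of the range that this assay can report; no number is known for it, only a limit, and the same holds for the two other measured compounds (the limit of > 30000 nM in this assay, at which 3 of the 3 values shown sit). Among the compounds with values here, the one step among measured compounds that changes a single place, a step that the two limits leave unreadable from compound 2 to compound 3, cannot be read in size or direction, since both ends are limits.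

Compound 4, `O=C(Nc1cccc(NC(=O)c2cccc(Cl)c2)c1)c1ccc(F)cc1`, is reached from compound 3 by the change (4-fluorophenyl in place of 3,4-dichlorophenyl on a carbonyl carbon). Within the data shown here, no measured step speaks to this change. Given that every measured compound sits at the limit, compound 4 is expected to remain there as well, its estimate being 30000 nM, with a range from 10000 nM to 100000 nM. This estimate means a step of a number no higher from compound 3 to compound 4 (the limit leaves the size open) that is expected to show no readable movement.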

Compound 4, half-maximal inhibitory concentration: > 30000 nM
Compound 4 gave a limit, no number (the forecaster's own chance of this, stated with the estimate: 85%); the middle value lies on the limit itself.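

Compound 4 also gives only a limit, so none of its steps to compound 1, compound 2 or compound 3 can be read in size or direction: the limit of > 30000 nM in this assay, at which 4 of the 4 values shown sit.

Which change to the shared core, if any, would give a measurable number in this assay remains open.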